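Adding a Methoxy Group to an Inactive Series

The compounds below may be only part of what the source reports. "The series", "measured", "known", "first", "only" and "open" are said of these compounds alone.

Of the compounds shown here, three share one core and have been tested in a functional assay on M21 cells (Homo sapiens) for antiproliferative activity, read by sulforhodamine B assay, with a stated time of 48 h; a lower number here means a stronger inhibitor of growth, a higher number a weaker inhibitor of growth. Compound 1 `NS(=O)(=O)NCC1CCN(c2cc(-c3ccccc3)ncn2)CC1` carries a plain phenyl group. In this assay compound 1 gives > 100000 nM, which is a limit of the assay rather than a number. Compound 2 `NS(=O)(=O)NCC1CCN(c2cc(-c3ccccc3F)ncn2)CC1` carries fluoro in place of hydrogen on an aromatic carbon. In this assay compound 2 gives > 100000 nM, again a limit. Compound 3 `NS(=O)(=O)NCCC1CCN(c2cc(-c3ccccc3)ncn2)CC1` carries (sulfamoylamino)methyl in place of sulfamoylamino on a saturated chain carbon. In this assay compound 3 gives > 100000 nM, also a limit. Because all three values sit at the limit of > 100000 nM in this assay, at which 3 of the 3 values shown sit, the steps a step that the two limits leave unreadable from compound 1 to compound 2 and a step that the two limits leave unreadable from compound 1 to compound 3 cannot be read in size. Compound 4 `COc1ccc(-c2cc(N3CCC(CCNS(N)(=O)=O)CC3)ncn2)cc1` differs from compound 3 by methoxy in place of hydrogen on an aromatic carbon, a change that reads as phenyl to 4-methoxyphenyl, placed para to a large group. Within the data shown here, no measured step speaks to this change, and nothing in the set shows any gain in potency. Compound 4 is therefore expected to give about 150000 nM, with a range from 30000 nM to 500000 nM, most likely reported as a limit once more. The expected step that the limit leaves unreadable from compound 3 to compound 4 is thus none beyond the scatter.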

Compound 4, concentration for 50% growth inhibition: 69800 nM
Beside the measured number, compound 4's estimate is 2.1-fold (0.33 log units) above it; measured number inside the range.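

Among these compounds, compound 4 is the only compound here that gives a number rather than a limit in this assay, so 4-methoxyphenyl in place of phenyl is the one change in the set with a measurable result. The step is an at least 1.4-fold lower number from compound 3 to compound 4 (0.15 log units; that floor lies within the scatter), so the true gap may be larger, but the data do not establish a gain beyond the scatter. The step can be given only as a floor because compound 3 stands at a limit: the limit of > 100000 nM in this assay, at which 3 of the 4 values shown sit.

From the compounds shown here alone, it remains open whether an ethoxy group, a hydroxyl group or an amine at the same place on the ring would give a lower number than methoxy. Going by these compounds, it also remains open whether methoxy would have any readable effect on compound 1, which has the shorter chain.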